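Arylidene diketopiperazine series: halophenyl variation and Huh-7 cytotoxicity

This account rests on a few compounds, and the source may have more. Where it says the series, first, only, none or still open, it means among the compounds named here.

Among the measured compounds shown here, compound 2 `C=CCn1c(=O)/c(=C\c2cccc(F)c2)[nH]c(=O)/c1=C\c1ccccc1OC` gives 27200 nM in a functional assay on Huh-7 cells (Homo sapiens) for cytotoxicity, read by CCK-8 assay, with a stated time of 72 h (on this read-out higher numbers stand for weaker inhibition and lower numbers for stronger inhibition), the highest of the two numbers so far; its nearest neighbour is compound 1 `C=CCn1c(=O)/c(=C\c2cccc(Cl)c2)[nH]c(=O)/c1=C\c1ccccc1OC`, which gives 8900 nM in this assay. For the measured compounds named here, the one measured step, a 3.1-fold higher number from compound 1 to compound 2 (0.49 log units; beyond the scatter), ties the halogen identity to the read-out. The next step to compound 3 `C=CCn1c(=O)/c(=C\c2ccccc2Cl)[nH]c(=O)/c1=C\c1ccccc1OC` is 2-chlorophenyl in place of 3-fluorophenyl on a double-bonded chain carbon bound to an aromatic carbon. It bears on the earlier step only in part: chlorine replaces fluorine again, as in the reverse of the step from compound 1 to compound 2, but within a differently named phenyl, 2-chlorophenyl instead of 3-fluorophenyl, for which no measurement exists. A lower number than compound 2 is therefore expected, probably of the size seen between compound 2 and compound 1, with widened uncertainty from the change of phenyl. Compound 3 is expected to give 12000 nM in this assay, within 4000 nM to 36000 nM, an expected step of a 2.3-fold lower number from compound 2 to compound 3 (0.36 log units; beyond the scatter).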

Compound 3, half-maximal inhibitory concentration: 6400 nM
Estimate against measurement, compound 3: 1.9-fold (0.27 log units) above; the measured number falls inside the stated range.
By their numbers in this assay, from the lowest: compounds 3 and 1 (each within the scatter of the next); then compound 2.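

In this assay, 2-chlorophenyl in place of 3-fluorophenyl on a double-bonded chain carbon bound to an aromatic carbon gives a 4.3-fold lower number from compound 2 to compound 3 (0.63 log units; beyond the scatter) and so places a second chlorophenyl on the lower-number side of the fluorinated compound. The change of 3-chlorophenyl to 2-chlorophenyl at the same carbon gives a 1.4-fold lower number from compound 1 to compound 3 (0.14 log units; within the scatter) and so leaves compound 1 and compound 3 indistinguishable, which means that moving the chlorine has no readable effect in this pair. No data at hand explain either step.

Still open, on these data alone, is how a phenyl bearing an amine or a carboxylic acid would behave at this carbon, and whether an unsubstituted phenyl would read closer to compound 2 or to the chlorophenyl pair. Also open, as far as these compounds go, is whether the 2-chlorophenyl result extends to other halogens.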